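The source may report more compounds than this note shows. Statements on the series, on what has been measured and on what is new or still open speak of the compounds shown alone.

Measured so far in a functional assay on HT-1080 cells (Homo sapiens) for cytotoxicity, read by MTT assay, with a stated time of 72 h; on this read-out lower numbers stand for stronger inhibition and higher numbers for weaker inhibition:
compound 1 `COc1cccc(/C=C2\CCC/C(=C\c3cccc(OC)c3OC)C2=O)c1` gives 9900 nM;
compound 2 `COc1cccc(/C=C2\CCC/C(=C\c3cccc(O)c3)C2=O)c1OC` gives 8500 nM;
compound 3 `COc1cc(/C=C2\CCC/C(=C\c3cccc(OC)c3OC)C2=O)ccc1O` gives 5900 nM.

The three numbers sit close together, and every step between them is within the scatter: a 1.2-fold lower number from compound 1 to compound 2 (0.07 log units; within the scatter), a 1.7-fold lower number from compound 1 to compound 3 (0.22 log units; within the scatter), a 1.4-fold lower number from compound 2 to compound 3 (0.16 log units; within the scatter). The core of compound 3 differs from that of compound 1 by hydroxy in place of hydrogen on an aromatic carbon.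

Compound 4 `COc1cccc(/C=C2\CCC/C(=C\c3ccc(O)c(O)c3)C2=O)c1OC` has not been measured. It differs from compound 3 by hydrogen in place of methyl on an oxygen on an aromatic ring. The same change, at a place described in the same words, is already made from compound 1 to compound 2: hydrogen in place of methyl on an oxygen on an aromatic ring, with the step of a 1.2-fold lower number from compound 1 to compound 2 (0.07 log units; within the scatter).

Among the measured compounds shown here, that earlier step is the only guide, so compound 4 is expected to stay near compound 3, with a step of about a 1.2-fold lower number from compound 3 to compound 4 (0.07 log units; within the scatter) in this assay, resting on a 1.2-fold lower number from compound 1 to compound 2 (0.07 log units; within the scatter). For compound 4 the estimate is 5000 nM, with a range from 2500 nM to 10000 nM.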

Compound 4, half-maximal inhibitory concentration: 4700 nM
Compound 4: the middle estimate sits 1.1-fold (0.03 log units) above what was measured, and the stated range covers the measured number.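

In this assay, methoxy to hydroxy on the core of compound 3 gives a 1.3-fold lower number from compound 3 to compound 4 (0.10 log units; within the scatter), and the step reads alike on both cores: the same change on two cores in this assay, a 1.2-fold lower number (0.07 log units; within the scatter) from compound 1 to compound 2 and a 1.3-fold lower number (0.10 log units; within the scatter) from compound 3 to compound 4, 1.1-fold (0.03 log units) apart, within the scatter of two such steps

Hydroxy in place of hydrogen on an aromatic carbon gives a 1.8-fold lower number from compound 2 to compound 4 (0.26 log units; within the scatter), and this step also reads alike on both cores: the same change on two cores in this assay, a 1.7-fold lower number (0.22 log units; within the scatter) from compound 1 to compound 3 and a 1.8-fold lower number (0.26 log units; within the scatter) from compound 2 to compound 4, 1.1-fold (0.03 log units) apart, within the scatter of two such steps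

Only the swap of 3-methoxyphenyl for 3,4-dihydroxyphenyl, a 2.1-fold lower number from compound 1 to compound 4 (0.32 log units; beyond the scatter), passes the scatter, and modestly; the agreement shows that these small steps stay small across two cores, not that either change has a real effect of fixed size or that it would carry to further cores.

The aromatic rings shown bear only methoxy and hydroxy, so an amine, a carboxylic acid or a fluorine in their place remains open. Also open, going by these compounds, is whether any such group moves the number well beyond the scatter.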